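A few compounds are considered here, and "the series" means these few. Any claim that something is new, unique, unknown or untested is made for them only; others in the source may bear on it.

In a functional assay on HOS-TE85 cells (Homo sapiens) for inhibition, read by CCK-8 assay, with a stated time of 72 h (a lower number here means a stronger inhibitor, a higher number a weaker inhibitor), compound 2 `C#Cc1cc(C(=O)NCCCCc2ccccc2)cc(C2SCC(=O)N2c2ccccc2OC)c1` reads 40.8 nM and compound 1 `COc1ccccc1N1C(=O)CSC1c1cc(C(=O)NCCCCc2ccccc2)cc(C2CC2)c1` reads 23.5 nM on the same scale, so the two cannot be told apart. Compound 3 `COc1ccccc1N1C(=O)CSC1c1cc(C)cc(C(=O)NCCCCc2ccccc2)c1` has methyl in place of ethynyl on an aromatic carbon, meta to two large groups (methyl in place of ethynyl on an aromatic carbon). Going by the values given here, the only measured step at this place (a 1.7-fold higher number from compound 1 to compound 2 (0.24 log units; within the scatter)) put ethynyl in place of cyclopropyl and stayed within the scatter, so no step beyond the scatter is expected in this assay here. In numbers the expected step is modest (a 1.2-fold lower number from compound 2 to compound 3 (0.07 log units; within the scatter)). For compound 3 the estimated value is 35 nM with 12 nM to 100 nM as its range.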

Compound 3, half-maximal inhibitory concentration: 16.2 nM
Beside the measured number, compound 3's estimate is 2.2-fold (0.33 log units) above it; measured number inside the range.
By their numbers in this assay, from the lowest: compounds 3, 1 and 2 (each within the scatter of the next, the first and the last beyond it).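

In this assay, this aromatic carbon now shows a step beyond the scatter, though a modest one: a 2.5-fold lower number from compound 2 to compound 3 (0.40 log units; beyond the scatter). The swap of methyl for ethynyl therefore registers here, whereas the swap of methyl for cyclopropyl does not, at a 1.5-fold lower number from compound 1 to compound 3 (0.16 log units; within the scatter). Nothing measured here accounts for this difference.

All three groups at this position contain only carbon and hydrogen. On these data alone, how an amine, a carboxylic acid or a longer alkyl chain on this carbon would read remains open.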